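Replacing the chloro group of compound 2

The source may report more compounds than this note shows. Statements on the series, on what has been measured and on what is new or still open speak of the compounds shown alone.

Compound 2 (`CCOC(=O)c1c(C(C)C)oc2nccc(N3CCN(c4ccc(Cl)cc4)CC3)c12`) gives > 234000 nM in an ADME assay on J774.A1 cells (Mus musculus) for cytotoxicity, read by fluorescence and resazurin assay, with a stated time of 24 h (a higher number here means a weaker inhibitor, a lower number a stronger inhibitor), and this is a limit, not a number. Compound 3 (`CCOC(=O)c1c(C(C)C)oc2nccc(N3CCN(c4ccccc4)CC3)c12`) has hydrogen in place of chloro on an aromatic carbon. Among the compounds with values here, compound 1 (`CCOC(=O)c1c(C)oc2nccc(N3CCN(c4ccccc4)CC3)c12`), which also carries phenyl, gives 120000 nM in this assay as the only number so far. Within the data shown here, no measured step isolates this change. Among the measured compounds shown here, with compound 1 at 120000 nM as the sole guide, a modest move to a lower number is expected, possibly none beyond the scatter. The estimate amounts to an at least 1.3-fold lower number from compound 2 to compound 3 (0.11 log units; that floor lies within the scatter) as an expected move. For compound 3 the expected value is 180000 nM with an estimated range of 80000 nM to 350000 nM as the working figures.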

Compound 3, half-maximal inhibitory concentration: 235000 nM
For compound 3 the middle estimate is 1.3-fold (0.12 log units) below the measured one, within the range that was stated.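

Compound 3 gives the series its first readable step in this assay: with isopropyl in place of methyl on an aromatic carbon, there is a 2.0-fold higher number from compound 1 to compound 3 (0.29 log units; within the scatter). The step from chloro to hydrogen cannot be read, since compound 2 has only a limit, not a number: the limit of > 234000 nM in this assay, at which 1 of the 3 values shown sits.

As far as these compounds go, whether chloro itself matters in this assay stays open without a number for compound 2. Also open, from the compounds shown here alone, is how an amine or a carboxylic acid in place of chloro on the phenyl would read, and whether a longer chain in place of isopropyl would move beyond the scatter.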